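Benzyl for Phenyl: Expected Tolerance of Compound 3

This account rests on a few compounds, and the source may have more. Where it says the series, first, only, none or still open, it means among the compounds named here.

Compound 1 `CC1=C(C(=O)Nc2cccc(Cl)c2)C(c2cnc(CS)n2Nc2ccccc2)NC(=O)N1`: 98600 nM
Compound 2 `CC1=C(C(=O)Nc2ccc(Cl)cc2)C(c2cnc(CS)n2Nc2ccccc2)NC(=O)N1`, reported only as a limit: > 100000 nM

Among the measured compounds shown here, in an ADME assay on Vero cells (Chlorocebus sabaeus) for cytotoxicity, read by XTT assay, with a stated time of 72 h (a higher number here means that more compound is tolerated, a lower number that less compound is tolerated), compound 1 gives 98600 nM, the only actual number among the two values shown. For compound 2 this assay reports a limit rather than a number, > 100000 nM. For the measured compounds named here, the single measured step, an at least 1.0-fold higher number from compound 1 to compound 2 (0.00 log units; that floor lies within the scatter), concerns the chlorophenyl on the amide-type nitrogen and rests on (the limit of > 100000 nM in this assay, at which 1 of the 2 values shown sits). Compound 3 `CC1=C(C(=O)Nc2cccc(Cl)c2)C(c2cnc(CS)n2NCc2ccccc2)NC(=O)N1` differs from compound 1 at another place: benzyl in place of phenyl on a nitrogen on an aromatic ring. That step does not bear on this change, which alters the substituent on the nitrogen on the aromatic ring rather than the chlorophenyl. For compound 3 no shift beyond the scatter is therefore expected, a 1.0-fold higher number from compound 1 to compound 3 (0.01 log units; within the scatter). Compound 3 is expected to give about 100000 nM in this assay, between 40000 nM and 250000 nM, with a real chance that only a limit is returned.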

Compound 3, half-maximal cytotoxic concentration: > 100000 nM
Compound 3 was reported as a limit (the forecaster's own chance of this, stated with the estimate: 55%); the middle value lies on the limit itself.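

In this assay, among the compounds shown here, the earlier compounds differed only in the chlorophenyl, so this is the first view of the substituent on the nitrogen on the aromatic ring. Here benzyl in place of phenyl gives an at least 1.0-fold higher number from compound 1 to compound 3 (0.00 log units; that floor lies within the scatter) and this floor is all that can be read of the step. It shows that going from anilino to benzylamino at this place does not bring the number down beyond the scatter, but the size of any rise stays hidden: the limit of > 100000 nM in this assay, at which 2 of the 3 values shown sit.

From the compounds shown here alone, whether a longer chain such as phenethyl on this nitrogen, or an amine or a carboxylic acid on the benzyl ring, would bring the number down stays open. The compounds shown also leave open how far above the limit of this assay compound 3 truly lies.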